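The compounds below may be only part of what the source reports. "The series", "measured", "known", "first", "only" and "open" are said of these compounds alone.

Compound 1 `CCc1ccc(NC2=CC(=O)c3nc4n(c3C2=O)[C@H]2OC[C@@H](O)[C@H]2OC4)cc1`: 3080 nM
Compound 2 `O=C1C=C(N2CCCCC2)C(=O)c2c1nc1n2[C@H]2OC[C@@H](O)[C@H]2OC1`: > 8000 nM

Both compounds were tested in a functional assay on ECa-109 cells for inhibition, with ECa-109 cell line (Homo sapiens) as the target, read by sulforhodamine B assay; on this read-out higher numbers stand for weaker inhibition and lower numbers for stronger inhibition. Compound 1 gives a real number there. Compound 2 reads > 8000 nM, which is a limit of the assay and not a number. Compound 2 therefore stands at the limit of > 8000 nM in this assay, at which 1 of the 2 values shown sits.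

The next compound, compound 3 `O=C1C=C(N2CCCC2)C(=O)c2c1nc1n2[C@H]2OC[C@@H](O)[C@H]2OC1`, changes only the saturated ring of compound 2: pyrrolidin-1-yl in place of piperidin-1-yl on a double-bonded ring carbon. In words, pyrrolidin-1-yl takes the place of piperidin-1-yl on a double-bonded ring carbon.

For the measured compounds named here, only one measured step bears on this, and only loosely. It is an at least 2.5-fold higher number from compound 1 to compound 2 (0.41 log units; beyond the scatter), which lies beyond the scatter and came with piperidin-1-yl replacing (4-ethylphenyl)amino. Going by the values given here, no measured pair compares the two ring sizes directly. Going by an at least 2.5-fold higher number from compound 1 to compound 2 (0.41 log units; beyond the scatter), compound 3 is expected to remain a weak inhibitor like compound 2, with no change beyond the scatter in this assay, and it may well also return only a limit.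

The estimated step is a step that the limit leaves unreadable from compound 2 to compound 3. Compound 3 is expected at about 9000 nM, with an estimated range of 4000 nM to 20000 nM.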

Compound 3, half-maximal inhibitory concentration: > 16000 nM
Compound 3 ended at the assay's limit; the forecaster's own chance of this, stated with the estimate: 65%; middle value at least 1.7-fold (0.24 log units) from the limit.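

In this assay compound 3 reads > 16000 nM, which is a limit of the assay and not a number. The result shows that weak inhibition at this double-bonded ring carbon is not confined to piperidin-1-yl: replacing the (4-ethylphenyl)amino group of compound 1 with the five-membered pyrrolidin-1-yl gives an at least 5.1-fold higher number from compound 1 to compound 3 (0.71 log units; beyond the scatter), so among these three compounds both saturated rings read weaker than the (4-ethylphenyl)amino group, and none goes against this. The two ring sizes themselves cannot be compared, as the step between compound 2 and compound 3 cannot be read when both end at limits.

Going by these compounds, it remains open how weak either compound truly is and whether the ring size matters at all. On these data alone, it is also open whether the aromatic ring, its ethyl group or the amine hydrogen of compound 1 carries the measurable inhibition, which a plain phenylamino group, a benzylamino group or an open-chain amine such as diethylamino at this carbon could help to separate.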